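Swapping the aminophenyl of compound 1 for a difluorophenyl

The source may hold more compounds than are shown below. What is called first, only, known or untested is meant among the compounds shown, and "the series" means these compounds.

Measured compounds:
compound 1, `COc1cc(-c2cc(/C=C/C(=O)c3ccc(N)cc3)[nH]n2)cc(OC)c1OC`, 76%
compound 2, `COc1ccc(-c2cc(/C=C/C(=O)c3ccc(N)cc3)[nH]n2)cc1OC`, 89%

In a functional assay on PC-3 cells (Homo sapiens) for cytotoxicity, read by sulforhodamine B assay, with a stated time of 48 h, tested at 1 uM (a lower number here means a stronger effect, a higher number a weaker effect of the compound at the concentration tested), compound 1 gives 76%, the lower of the two numbers shown, which means the stronger effect of the pair. Compound 2 gives 89%. Among the measured compounds shown here, the only measured step, a number 13 percentage points higher from compound 1 to compound 2 (beyond the scatter), comes from hydrogen in place of methoxy on an aromatic carbon and lies beyond the scatter, yet it is of modest size.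

Compound 3 is `COc1cc(-c2cc(/C=C/C(=O)c3ccc(F)c(F)c3)[nH]n2)cc(OC)c1OC`. It differs from compound 1 in this way: 3,4-difluorophenyl in place of 4-aminophenyl on a carbonyl carbon. The measured step from compound 1 to compound 2 concerns a different part of the molecule, the methoxy-bearing ring, and so says nothing direct about exchanging the ring on the carbonyl carbon. There is no measured change of this kind to lean on.

For the measured compounds named here, with no guiding step, the expectation for compound 3 is a number close to that of compound 1, with a wide range to either side; the estimated step is a number 4 percentage points higher from compound 1 to compound 3 (within the scatter). The estimate for compound 3 in this assay is 80%, expected to fall between 58% and 100%.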

Compound 3, a percentage reported as activity, at one concentration (the size of the read-out at that concentration, not a potency): 70%
Beside the measured number, compound 3's estimate is 10 percentage points above it; low and high end bracket the measured number.
By their numbers in this assay, from the lowest: compounds 3 and 1 (each within the scatter of the next); then compound 2.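

In this assay, the ring on the carbonyl carbon can be exchanged without a clear shift in the read-out: a number 6 percentage points lower from compound 1 to compound 3 (within the scatter), with 3,4-difluorophenyl in place of 4-aminophenyl. Compound 1 and compound 2 differ only in a methoxy group, so this pair is the one that speaks to the ring on the carbonyl carbon, and it shows that the read-out at this concentration does not depend on keeping 4-aminophenyl there, even though the entering group counts 0 hydrogen-bond donors and 0 hydrogen-bond acceptors where the leaving group counts 1 of each. Nothing available here explains why these two rings give readings within the usual scatter of each other.

Still open, from the compounds shown here alone, is how far this tolerance extends, since a ring on the carbonyl carbon bearing a carboxylic acid, a morpholine or a single fluorine would test groups quite unlike these two. Also open, going by these compounds, is whether 3,4-difluorophenyl would behave the same way on the core of compound 2, which carries one methoxy group fewer.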